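A few compounds are considered here, and "the series" means these few. Any claim that something is new, unique, unknown or untested is made for them only; others in the source may bear on it.

In a functional assay on A549 cells (Homo sapiens) for inhibition, read by sulforhodamine B assay, with a stated time of 48 h (on this read-out higher numbers stand for weaker inhibition of growth and lower numbers for stronger inhibition of growth), the measured compounds are:
Compound 1 `COc1cc(-c2nn(-c3cccc(NC(=O)Nc4cc(C(F)(F)F)cc(C(F)(F)F)c4)c3)cc2-c2ccncc2)ccc1Cl` gives 527 nM
Compound 2 `COc1cc(-c2nn(-c3cccc(NC(=O)c4cccc(C(F)(F)F)c4)c3)cc2-c2ccncc2)ccc1Cl` gives 1870 nM

Compound 2 stands highest of the two, with compound 1 lower by more than the scatter. Compound 3 `COc1cc(-c2nn(-c3cccc(NC(=O)c4ccc(Cl)c(C(F)(F)F)c4)c3)cc2-c2ccncc2)ccc1Cl` differs from compound 2 by chloro in place of hydrogen on an aromatic carbon in one place: chloro in place of hydrogen on an aromatic carbon, ortho to a trifluoromethyl group. Within the data shown here, no measured step shows this change, so only a modest move toward stronger inhibition of growth is expected, an estimated 1.7-fold lower number from compound 2 to compound 3 (0.23 log units; within the scatter) in size. Compound 3 is expected at 1100 nM with an estimated range from 400 nM to 2800 nM in this assay's read-out.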

Compound 3, concentration for 50% growth inhibition: 2400 nM
Beside the measured number, compound 3's estimate is 2.2-fold (0.34 log units) below it, and the stated range covers the measured number.
By their numbers in this assay, from the lowest: compound 1; then compounds 2 and 3 (each within the scatter of the next).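

In this assay, chloro in place of hydrogen on an aromatic carbon, ortho to a trifluoromethyl group, gives a 1.3-fold higher number from compound 2 to compound 3 (0.11 log units; within the scatter), so the two compounds cannot be told apart. At this position, the 4-chloro-3-(trifluoromethyl)phenyl group thus reads the same as the 3-(trifluoromethyl)phenyl group. Nothing available here speaks to the reason for this result. On these data alone, whether an amine, a methoxy group or a carboxylic acid at this position would separate from compound 2 remains open. Also open, as far as these compounds go, is whether chloro would read the same on the other carbons of this ring.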